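Working notes: the step from compound 3 to compound 4

The source may report more compounds than this note shows. Statements on the series, on what has been measured and on what is new or still open speak of the compounds shown alone.

compound 1 `CCOC(=O)C(C)Oc1c(-c2ccc(OC)cc2)oc2c(CC=C(C)C)c(O)cc(O)c2c1=O`: 6500 nM
compound 2 `COc1ccc(-c2oc3c(CC=C(C)C)c(OCCOC(=O)CCC(=O)O)cc(O)c3c(=O)c2OCCOC(=O)CCC(=O)O)cc1`: "not determined" (no result reported)
compound 3 `CCOC(=O)C(C)Oc1cc(O)c2c(=O)c(O)c(-c3ccc(OC)cc3)oc2c1CC=C(C)C`: 1400 nM

In an ADME assay on Vero cells (Chlorocebus sabaeus) for cytotoxicity, read by MTT assay (a higher number here means a weaker inhibitor, a lower number a stronger inhibitor), compound 3 gives 1400 nM, the lower of the two numbers available, and the gap up to compound 1 lies beyond the scatter. Compound 4 `CCOC(=O)COc1cc(O)c2c(=O)c(O)c(-c3ccc(OC)cc3)oc2c1CC=C(C)C` differs from compound 3 by hydrogen in place of methyl on a saturated chain carbon bound to a carbonyl carbon and an oxygen on an aromatic ring: hydrogen in place of methyl, so that 1-(ethoxycarbonyl)ethoxy becomes (ethoxycarbonyl)methoxy. For the measured compounds named here, no measured pair isolates this change, so the expectation is weakly founded. A small rise in the number is expected, not beyond the scatter, and the expected change is a 1.3-fold higher number from compound 3 to compound 4 (0.11 log units; within the scatter). The estimated value for compound 4 is 1800 nM, with an expected range of 700 nM to 5000 nM.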

Compound 4, half-maximal inhibitory concentration: 1400 nM
Estimate against measurement, compound 4: 1.3-fold (0.11 log units) above; the measured number falls inside the stated range.
By their numbers in this assay, from the lowest: compounds 3 and 4 (each within the scatter of the next); then compound 1.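

In this assay the step reads no change at the digits printed from compound 3 to compound 4 (within the scatter), so hydrogen in place of methyl on this saturated chain carbon makes no measurable difference, and 1-(ethoxycarbonyl)ethoxy and (ethoxycarbonyl)methoxy read alike here. The earlier compounds shown here offered no pair isolating this change. Nothing measured here offers an explanation for the result.

Still open, from the compounds shown here alone, is whether a larger group on this carbon, such as phenyl, or a carboxylic acid in place of the ethyl ester, would read the same. This single pair also cannot show whether the change would read alike on compound 1.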